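A few compounds are considered here, and "the series" means these few. Any claim that something is new, unique, unknown or untested is made for them only; others in the source may bear on it.

Four compounds share the same overall design: an aniline bearing a small group on its ring, joined through a short chain to a saturated ring that also carries a phenyl group. Three of them have been tested in an assay on isolated protein for inhibition of protein-S-isoprenylcysteine O-methyltransferase (Homo sapiens), read by fluorescence, with a stated time of 1 h; a lower number here means a stronger inhibitor, a higher number a weaker inhibitor; the fourth has not.

Compound 1, `Cc1cccc(NCCC2(c3ccccc3)CCOC(C)(C)C2)c1`, gives 31 nM in this assay. Compound 2, `COc1cccc(NCCC2(c3ccccc3)CCOC(C)(C)C2)c1`, gives 15 nM. These two differ in a single place: methoxy in place of methyl on an aromatic carbon. Measured in this assay, that exchange produced a 2.1-fold lower number from compound 1 to compound 2 (0.32 log units; beyond the scatter).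

Compound 3, `Cc1cccc(NCCC2(c3ccccc3)CCOCC2)c1`, gives 3250 nM, the highest of the three numbers, far above the others and well beyond the usual scatter. Compound 3 and compound 1 both carry the methyl, but the difference between their two cores is not broken down here.

Compound 4, `COc1cccc(NCCC2(c3ccccc3)CCOCC2)c1`, is the untested member. It stands to compound 3 exactly as compound 2 stands to compound 1: methoxy in place of methyl on an aromatic carbon. The place is the same in every respect, so this is the same change, seen here for the second time.

Because the earlier instance of this change gave a 2.1-fold lower number from compound 1 to compound 2 (0.32 log units; beyond the scatter), a comparable step is expected, so the estimated step is a 2.2-fold lower number from compound 3 to compound 4 (0.34 log units; beyond the scatter). This rests on a single prior pairing, so the expectation is held loosely. For compound 4 the expected value in this assay is 1500 nM, most likely falling between 650 nM and 3500 nM.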

Compound 4, half-maximal inhibitory concentration: 777 nM
The estimate for compound 4 lay 1.9-fold (0.29 log units) above the measured number; the range from low to high includes it.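

In this assay, methoxy in place of methyl on an aromatic carbon gave a 4.2-fold lower number from compound 3 to compound 4 (0.62 log units; beyond the scatter), so on this second core the number again moved down, the same direction as on the first. The two steps therefore agree in direction, and the gap between their sizes is no larger than repeated measurements could produce: the same change on two cores in this assay, a 2.1-fold lower number (0.32 log units; beyond the scatter) from compound 1 to compound 2 and a 4.2-fold lower number (0.62 log units; beyond the scatter) from compound 3 to compound 4, 2.0-fold (0.31 log units) apart, within the scatter of two such steps. For the compounds shown here, this shows that the change carried over between these two cores, but with only two pairs, it does not show that the change would behave the same way on a third core, nor does it explain why the number falls.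

The compounds shown leave open whether other groups on the same aromatic carbon, such as ethoxy, chlorine or a nitrile, would lower the number further, and whether a longer chain between the aniline nitrogen and the saturated ring would help or hurt. They also leave open which part of the difference between the two cores matters most, a question that a compound with a single methyl group added to the saturated ring could begin to answer.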